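A few compounds are considered here, and "the series" means these few. Any claim that something is new, unique, unknown or untested is made for them only; others in the source may bear on it.

Measured so far in an assay on isolated protein for inhibition of lysosomal alpha-glucosidase (Rattus norvegicus), tested at 100 uM; on this read-out lower numbers stand for less inhibition and higher numbers for more inhibition at the one concentration tested (going by the name of the read-out):
- compound 1 `O=C(/C=C/c1ccccc1)C[C@@H]1O[C@H](CO)[C@@H](O[C@@H]2O[C@H](CO)[C@@H](O)[C@H](O)[C@H]2O)[C@H](O)[C@H]1O`: -24.6%
- compound 2 `CCOC(=O)C(C(=O)OCC)C(CC(=O)C[C@@H]1O[C@H](CO)[C@@H](O)[C@H](O)[C@H]1O)c1ccc(Cl)cc1`: -10%
- compound 3 `O=C(/C=C/c1ccc2ccccc2c1)C[C@@H]1O[C@H](CO)[C@@H](O)[C@H](O)[C@H]1O`: -16.9%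

Compound 2 carries the highest of the three numbers; its gap to compound 3 lies within the scatter, so no order between those two can be read, while its gap to compound 1 lies beyond the scatter. All three numbers are negative.

Compound 4 `CCOC(=O)C(C(=O)OCC)C(CC(=O)C[C@@H]1O[C@H](CO)[C@@H](O)[C@H](O)[C@H]1O)c1ccc2ccccc2c1` is not yet measured. It differs from compound 2 in one place: naphthalen-2-yl in place of 4-chlorophenyl on a saturated chain carbon bound to two saturated chain carbons. Within the data shown here, no step between two measured compounds covers this change. The numbers shown give no ground for a shift in this assay beyond the scatter, in either direction. Compound 4 is therefore estimated at -13%, expected between -30% and 5%, an expected step of a number 3 percentage points lower from compound 2 to compound 4 (within the scatter).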

Compound 4, a percentage reported as inhibition, at one concentration (the size of the read-out at that concentration, not a potency): -20%
Compound 4: the middle estimate sits 7 percentage points above what was measured, and the stated range covers the measured number.
By their numbers in this assay, from the lowest: compounds 1, 4, 3 and 2 (each within the scatter of the next, the first and the last beyond it).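

In this assay, naphthalen-2-yl in place of 4-chlorophenyl on a saturated chain carbon bound to two saturated chain carbons gives a number 10 percentage points lower from compound 2 to compound 4 (within the scatter), the first step read at this position. The second aromatic ring therefore brings no shift that can be separated from the scatter, and both compounds remain negative. Nothing at hand bears on the reason for this result.

From the compounds shown here alone, whether a cyclohexyl ring or an amine on this carbon would move the number remains open. So does whether any group here gives a positive number.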